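From 3-methoxyphenyl to 2-chloro-6-fluorophenyl

A few compounds are considered here, and "the series" means these few. Any claim that something is new, unique, unknown or untested is made for them only; others in the source may bear on it.

Compound 1 `COc1cccc(-c2cc(-c3c(O)c4ccccc4oc3=O)nc(O)n2)c1`: 5550 nM
Compound 2 `COc1cccc(-c2cc(-c3c(O)c4ccccc4oc3=O)nc(S)n2)c1`: 10200 nM

In a functional assay on A549 cells (Homo sapiens) for cytotoxicity, read by MTT assay (on this read-out higher numbers stand for weaker inhibition and lower numbers for stronger inhibition), compound 2 stands level with compound 1, since the measured step, a 1.8-fold higher number from compound 1 to compound 2 (0.26 log units; within the scatter), stays inside the usual scatter. Compound 3 `O=c1oc2ccccc2c(O)c1-c1cc(-c2c(F)cccc2Cl)nc(S)n1` changes another place: 2-chloro-6-fluorophenyl in place of 3-methoxyphenyl on an aromatic carbon. Within the data shown here, that measured step exchanged hydroxy for sulfanyl, so no measured compound shows what this new group does, and the small size of that step is only weak guidance. No shift beyond the scatter is therefore expected in this assay. The expected step is a 1.3-fold lower number from compound 2 to compound 3 (0.11 log units; within the scatter). For compound 3 the estimated value is 8000 nM, with an expected range of 2500 nM to 25000 nM.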

Compound 3, half-maximal inhibitory concentration: 3980 nM
Compound 3: middle estimate off by 2.0-fold (0.30 log units), on the high side; the measured number falls inside the stated range.
By their numbers in this assay, from the lowest: compounds 3, 1 and 2 (each within the scatter of the next, the first and the last beyond it).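

In this assay the exchange of 3-methoxyphenyl for 2-chloro-6-fluorophenyl gives a 2.6-fold lower number from compound 2 to compound 3 (0.41 log units; beyond the scatter) and so moves the number beyond the scatter, which the exchange of hydroxy for sulfanyl with a 1.8-fold higher number from compound 1 to compound 2 (0.26 log units; within the scatter) did not do. This place therefore responds to its substituent, though only modestly and in a single pair, which cannot separate the effect of the chlorine from that of the fluorine. No measurement shown bears on why the number moves. As far as these compounds go, whether the shift persists with hydroxy in place of sulfanyl remains open. So does the outcome of an amine or a carboxylic acid on this phenyl ring.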